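From cyclopentyl to cyclohexyl on the amide nitrogen

This account rests on a few compounds, and the source may have more. Where it says the series, first, only, none or still open, it means among the compounds named here.

In a functional assay on BXPC-3 cells (Homo sapiens) for cytotoxicity, read by fluorescence, with a stated time of 48 h (a lower number here means that less compound is needed, a higher number that more compound is needed for the effect), compound 1 `CC(C)=CCC/C(C)=C/CC/C(C)=C/CSC[C@H](NC(=O)CCCCCN1CCN(C)CC1)C(=O)N1CCCCC1` gives 8800 nM. Compound 2 `CC(C)=CCC/C(C)=C/CC/C(C)=C/CSC[C@H](NC(=O)CCCCCN1CCN(C)CC1)C(=O)NC1CCCC1` reads > 20000 nM, which is a limit of the assay and not a number. For the measured compounds named here, the only measured step is an at least 2.2-fold higher number from compound 1 to compound 2 (0.35 log units; beyond the scatter), and its full size stays open.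

Compound 3 `CC(C)=CCC/C(C)=C/CC/C(C)=C/CSC[C@H](NC(=O)CCCCCN1CCN(C)CC1)C(=O)NC1CCCCC1` carries cyclohexyl in place of cyclopentyl on an amide-type nitrogen. Going by the values given here, no measured step covers this ring change directly. The expectation therefore rests on compound 2, with its reading of > 20000 nM, and compound 3 is expected to stay high in this assay, close to that limit. It may well return only a limit again. If a number is reported, a small step towards a lower number is expected: an at least 1.3-fold lower number from compound 2 to compound 3 (0.12 log units; that floor lies within the scatter). For compound 3 the estimate is 15000 nM, with an expected range of 7000 nM to 30000 nM.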

Compound 3, half-maximal effective concentration: 12000 nM
For compound 3 the middle estimate is 1.3-fold (0.10 log units) above the measured one, and the stated range covers the measured number.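

Moving from cyclopentyl to cyclohexyl on the amide-type nitrogen brings the reading in this assay off the limit, with an at least 1.6-fold lower number from compound 2 to compound 3 (0.22 log units; that floor lies within the scatter), so this ring change may matter, but its full size stays open. Compound 2 remains a limit of the assay and not a number: the limit of > 20000 nM in this assay, at which 1 of the 3 values shown sits.

The earlier step away from piperidin-1-yl does not hold for every amine on this carbonyl carbon, as cyclohexylamino gives a 1.4-fold higher number from compound 1 to compound 3 (0.13 log units; within the scatter), and these two groups cannot be told apart here.

The compounds shown leave open whether a cycloheptyl ring or a tert-butyl group on the amide-type nitrogen would keep this level. They also leave open whether a morpholin-4-yl group in place of piperidin-1-yl, or a shorter chain to the far amine, would shift the reading.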